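The compounds below may be only part of what the source reports. "The series", "measured", "known", "first", "only" and "open" are said of these compounds alone.

Compound 1 `CC(C)c1onc(-c2c(Cl)cccc2Cl)c1COc1ccc(N(C)Cc2ccc(OCCO)cc2)c(C(F)(F)F)n1`: 164 nM
Compound 2 `CN(Cc1ccc(C(=O)O)cc1)c1ccc(OCc2c(-c3c(Cl)cccc3Cl)noc2C2CC2)nc1C(F)(F)F`: 12 nM

In an assay on isolated protein for agonist activity at Bile acid receptor (Homo sapiens), read by FRET (a higher number here means that more compound is needed for the effect, a lower number that less compound is needed), compound 2 gives 12 nM, the lower of the two numbers; compound 1 gives 164 nM, a gap well beyond the usual scatter. Compound 3 `CC(Oc1cccc(C(=O)O)c1)c1ccc(OCc2c(-c3c(Cl)cccc3Cl)noc2C2CC2)nc1C(F)(F)F` is not yet measured. It differs from compound 2 by 1-(3-carboxyphenoxy)ethyl in place of (4-carboxybenzyl)(methyl)amino on an aromatic carbon. Going by the values given here, since no measured pair isolates this change, only a rough expectation is possible: in this assay compound 3 is expected to need somewhat more compound than compound 2, a step of a 3.3-fold higher number from compound 2 to compound 3 (0.52 log units; beyond the scatter), with an estimated value of 40 nM and a likely range from 10 nM to 200 nM.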

Compound 3, half-maximal effective concentration: 155 nM
Beside the measured number, compound 3's estimate is 3.9-fold (0.59 log units) below it; low and high end bracket the measured number.
By their numbers in this assay, from the lowest: compound 2; then compounds 3 and 1 (each within the scatter of the next).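

In this assay the exchange at this position brings a 13-fold higher number from compound 2 to compound 3 (1.11 log units; beyond the scatter), a large step, even though the leaving and entering groups match in heavy atoms, hydrogen-bond donors and acceptors, and each carries one aromatic ring of carbon only. This position, ortho to a trifluoromethyl group, therefore responds to how the group is built, not just to those counts. Nothing measured here explains the step. The exchange alters both the linking atoms and the place of the carboxy group, so the compounds shown cannot separate the two. On these data alone, whether an amide could stand in for the carboxylic acid also stays open.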